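The source may report more compounds than this note shows. Statements on the series, on what has been measured and on what is new or still open speak of the compounds shown alone.

Three compounds built on the same saturated, oxygen-containing ring have been tested in a functional assay on HeLa cells (Homo sapiens) for antiproliferative activity, read by sulforhodamine B assay; on this read-out lower numbers stand for stronger inhibition of growth and higher numbers for weaker inhibition of growth. Compound 1, `CCC[C@H]1O[C@H](COCc2ccc(F)cc2)[C@@H](OCc2ccc(F)cc2)[C@H](OCc2ccc(F)cc2)[C@H]1O`, gives 5600 nM in this assay. Compound 2, `CCC[C@@H]1O[C@H](CO)[C@@H](O)[C@H](O)[C@H]1O`, reaches only the limit of this assay, reported as > 50000 nM. Compound 3, `CCCC[C@@H]1O[C@H](COCc2ccccc2)[C@@H](OCc2ccccc2)[C@H](OCc2ccccc2)[C@H]1O`, likewise reaches only the limit of this assay, reported as > 50000 nM. Compound 3 therefore stands at the weak end of the numbers shown, sitting at the limit of > 50000 nM in this assay, at which 2 of the 3 values shown sit. Of the three, only compound 1 yields a measured concentration rather than a limit.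

The next compound, compound 4, `O[C@@H]1[C@@H](OCc2ccccc2)[C@H](OCc2ccccc2)[C@@H](COCc2ccccc2)O[C@H]1Cc1ccccc1`, differs from compound 3 in a single place: phenyl in place of propyl on a saturated chain carbon bound to a saturated ring carbon. Within the data shown here, no step between measured compounds matches this change, so its effect in this assay is uncertain. A modest step toward stronger inhibition of growth is expected, an at least 2.5-fold lower number from compound 3 to compound 4 (0.39 log units; beyond the scatter), though an outcome that leaves compound 4 at the limit would not be surprising. Compound 4 is expected to give about 20000 nM in this assay, within a range from 4000 nM to 50000 nM.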

Compound 4, concentration for 50% growth inhibition: 17400 nM
Estimate against measurement, compound 4: 1.1-fold (0.06 log units) above; low and high end bracket the measured number.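

Phenyl in place of propyl, on a saturated chain carbon bound to a saturated ring carbon, gives an at least 2.8-fold lower number from compound 3 to compound 4 (0.45 log units; beyond the scatter) in this assay. Among these compounds, this is the first sign that the group at this place can change growth inhibition; no earlier pair of compounds differed in one place only. The true size of the step stays unknown, and it can be read only as a lower bound, because compound 3 gives a limit and not a number: the limit of > 50000 nM in this assay, at which 2 of the 4 values shown sit.

The compounds shown leave open whether an aromatic ring is needed at this place or a longer saturated chain, such as hexyl, would serve as well. They also leave open how an amine or a carboxylic acid in place of the phenyl would read in this assay.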